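The compounds below may be only part of what the source reports. "The series", "measured", "known", "first", "only" and "open" are said of these compounds alone.

Measured compounds:
- compound 1 `O=C1CSC(c2cccc(O)c2)N1CCN1CCCCC1`, with 100% in an ADME assay on Vero cells (Chlorocebus sabaeus) for cytotoxicity, read by neutral red uptake, tested at 98 ug/mL; on this read-out higher numbers stand for a weaker effect at the one concentration tested and lower numbers for a stronger effect
- compound 2 `COc1ccccc1C1SCC(=O)N1CCN1CCCCC1`, with 100% in this assay

Of the compounds shown here, two sharing the same core have been run in this assay so far. Compound 1 gives 100%, and compound 2 gives 100%; the two values agree at the digits reported, so the difference between them lies within the scatter and no order between the two can be drawn from them. Within the data shown here, compound 1 therefore stands level with its only measured neighbour, compound 2, and both read-outs show essentially no cytotoxic effect at the single concentration tested.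

The next compound, compound 3 `O=C1CSC(c2ccc(Cl)cc2)N1CCN1CCCCC1`, differs from compound 1 in one place: 4-chlorophenyl in place of 3-hydroxyphenyl on a saturated ring carbon. Among the measured compounds shown here, no measured pair in this set tracks a 4-chlorophenyl replacing a 3-hydroxyphenyl on a saturated ring carbon, so the expected size of the step rests only on the two values already in hand, which both sit at the top of the read-out. The step from compound 1 to compound 3 is expected to be small, at most a slight fall, a number 4 percentage points lower from compound 1 to compound 3 (within the scatter). Compound 3 is accordingly estimated at 96%, with a range from 78% to 104%.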

Compound 3, a percentage reported as activity, at one concentration (the size of the read-out at that concentration, not a potency): 74%
Compound 3: middle estimate off by 22 percentage points, on the high side, outside the stated range (below it).
By their numbers in this assay, from the lowest: compound 3; then compounds 1 and 2 (each within the scatter of the next).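

In this assay, 4-chlorophenyl in place of 3-hydroxyphenyl on the saturated ring carbon gives a number 26 percentage points lower from compound 1 to compound 3 (beyond the scatter), so this position is not indifferent to the group it carries. Among these compounds, compound 3 is the first compound on the shared core whose read-out comes down from the top of the scale, which shows that an effect can be seen at the one concentration tested and that the series is not uniformly flat there. The change swaps a hydroxyl, with its hydrogen-bond donor and acceptor, for a chlorine and also moves the substituent around the phenyl ring, but nothing available bears on why the read-out moved.

On these data alone, whether the fall follows the arrival of the chlorine, the loss of the hydroxyl or the new place on the phenyl ring stays open, since this one step changes all three together. How a 3-chlorophenyl, a 4-hydroxyphenyl or an unsubstituted phenyl would read at this position would separate these, and a 4-bromophenyl or 4-fluorophenyl would show whether other halogens behave like the chlorine.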